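A few compounds are considered here, and "the series" means these few. Any claim that something is new, unique, unknown or untested is made for them only; others in the source may bear on it.

Working notes on the series, read in a functional assay on MCF7 cells (Homo sapiens) for inhibition, read by CCK-8 assay, with a stated time of 48 h; a lower number here means a stronger inhibitor of growth, a higher number a weaker inhibitor of growth. Compound 1 `Cc1ccccc1Nc1nc(Nc2cc(Cl)ccn2)ncc1Cl` returns only a limit of the assay, > 100000 nM; this is the line (the limit of > 100000 nM in this assay, at which 1 of the 2 values shown sits), and it counts as a limit and not as a number. Within the data shown here, compound 2 `CN1CCN(c2ccc(Nc3ncc(Cl)c(NCc4ccc(C(F)(F)F)cc4)n3)nc2)CC1` gives 28400 nM in this assay, the only number measured so far in the set. Compound 3 `CN1CCN(c2ccc(Nc3ncc(Cl)c(Nc4ccc(C(C)(C)C)cc4)n3)nc2)CC1` has not yet been measured. It differs from compound 2 in one place: 4-(tert-butyl)phenyl in place of 4-(trifluoromethyl)benzyl on a nitrogen on an aromatic ring. No step between measured compounds is available, so no measured change guides the forecast, and the exchange of 4-(tert-butyl)phenyl for 4-(trifluoromethyl)benzyl on a nitrogen on an aromatic ring has no counterpart among the two results shown. The expected step is a 1.9-fold lower number from compound 2 to compound 3 (0.28 log units; within the scatter), leaning toward a lower number but not clearly beyond the usual scatter, with wide uncertainty in either direction. Compound 3 is estimated to give 15000 nM in this assay, with the likely range running from 4000 nM to 60000 nM.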

Compound 3, concentration for 50% growth inhibition: 12600 nM
For compound 3 the middle estimate is 1.2-fold (0.08 log units) above the measured one; the measured number falls inside the stated range.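

In this assay, among these compounds, the exchange of 4-(trifluoromethyl)benzyl for 4-(tert-butyl)phenyl on a nitrogen on an aromatic ring gives the only step between measured compounds: a 2.3-fold lower number from compound 2 to compound 3 (0.35 log units; beyond the scatter). This shows that the number responds to the group at this position, though only modestly, with the step lying beyond the scatter and toward stronger inhibition of growth. No measurement shown bears on why the number moves with this exchange.

The step changes two features together, the ring substituent and the presence of the benzyl carbon on the nitrogen, and the compounds shown cannot separate them; 4-(trifluoromethyl)phenyl or 4-(tert-butyl)benzyl at the same position would divide the step into its two parts. Among the compounds shown here, also open is how far this position reaches in either direction, since only two groups with a carbon-only aromatic ring are compared here, and a cyclohexyl ring, a pyridine ring or a phenyl ring carrying a carboxylic acid could show whether the aromatic ring or the bulky substituent matters at all.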